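A few compounds are considered here, and "the series" means these few. Any claim that something is new, unique, unknown or untested is made for them only; others in the source may bear on it.

Measured in a functional assay on V79 cells (Cricetulus griseus), read by MTT assay, in the presence of a further agent that is not named here; a higher number here means a weaker inhibitor, a lower number a stronger inhibitor:
- compound 1 (`Cn1cc(-c2nc(C(N)=O)cs2)c2c1C(=O)C=C(N)C2=O`): 6200 nM
- compound 2 (`CCOC(=O)c1csc(-c2cn(C)c3c2C(=O)C(OC)=CC3=O)n1`): 423000 nM

Compound 2 holds the higher of the two numbers, and compound 1 lies below it by a margin beyond the scatter, making compound 2 the weaker inhibitor of this pair. Compound 3 (`COC1=CC(=O)c2c(c(-c3nc(C)cs3)cn2C)C1=O`) differs from compound 2 in one place: methyl in place of ethoxycarbonyl on an aromatic carbon. Within the data shown here, no two measured compounds differ in only one place, so the data offer no direct guide to this change. With compound 2 at 423000 nM as the higher number, a moderate move to a lower number in this assay is expected, though a step within the scatter remains possible. The expected change runs a 3.8-fold lower number from compound 2 to compound 3 (0.58 log units; beyond the scatter) and is only a rough estimate. Compound 3 is estimated at 110000 nM (range 20000 nM to 500000 nM).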

Compound 3, half-maximal inhibitory concentration: 72900 nM
For compound 3 the middle estimate is 1.5-fold (0.18 log units) above the measured one, within the range that was stated.
By their numbers in this assay, from the lowest: compound 1; then compound 3; then compound 2.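

Among these compounds, replacing ethoxycarbonyl with methyl on the aromatic carbon next to the ring nitrogen gives, in this assay, a 5.8-fold lower number from compound 2 to compound 3 (0.76 log units; beyond the scatter), the only change in a single place that can be read here. It shows that this position is not indifferent to its group in this assay: the step is modest but beyond the scatter, and the single carbon of methyl goes with the stronger inhibitor of this pair. Nothing available accounts for the step. From the compounds shown here alone, whether a carboxylic acid, an amine or a longer chain on this carbon would give a lower or a higher number remains open. Compound 1 differs from compound 2 and compound 3 in more than one place, so it cannot show whether this step holds on another core.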